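Ester for Alcohol on the Piperidine Tail

The source may report more compounds than this note shows. Statements on the series, on what has been measured and on what is new or still open speak of the compounds shown alone.

Two analogues that share one core have been measured in a functional assay on DU-145 cells (Homo sapiens) for antiproliferative activity, read by MTT assay, with a stated time of 72 h; a lower number here means a stronger inhibitor, a higher number a weaker inhibitor. Compound 1 `CCN(CC)CCCOc1cc2ncnc(Nc3ccc(C#N)cc3)c2cc1OC` gives 68900 nM. Compound 2 `COc1cc2c(Nc3ccc(C#N)cc3)ncnc2cc1OCCCN1CCC(CO)CC1`, which carries a 4-(hydroxymethyl)piperidin-1-yl in place of the diethylamino, gives 53200 nM. The step of a 1.3-fold lower number from compound 1 to compound 2 (0.11 log units; within the scatter) shows that exchanging the amine at the end of the chain stayed within the scatter, so compound 2 holds the lower of the two numbers without standing apart from compound 1. Compound 3 `CCOC(=O)C1CCN(CCCOc2cc3ncnc(Nc4ccc(C#N)cc4)c3cc2OC)CC1` has not been measured; it differs from compound 2 by ethoxycarbonyl in place of hydroxymethyl on a saturated ring carbon. Going by the values given here, only one measured step bears on this, and it touched the same end of the molecule while staying flat, so no step beyond the scatter is expected in this assay in either direction. Compound 3 is therefore estimated at 55000 nM, within 25000 nM to 120000 nM, an expected step of a 1.0-fold higher number from compound 2 to compound 3 (0.01 log units; within the scatter).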

Compound 3, half-maximal inhibitory concentration: 52300 nM
The estimate for compound 3 lay 1.1-fold (0.02 log units) above the measured number; the range from low to high includes it.
By their numbers in this assay, from the lowest: compounds 3, 2 and 1 (each within the scatter of the next).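

In this assay the exchange on the saturated ring carbon gives a 1.0-fold lower number from compound 2 to compound 3 (0.01 log units; within the scatter), so a larger ethoxycarbonyl with no hydrogen-bond donor stands in for hydroxymethyl without a step beyond the scatter. Measured against the diethylamino end of the chain, the new tail gives a 1.3-fold lower number from compound 1 to compound 3 (0.12 log units; within the scatter), and all three compounds now lie within the scatter of one another, which extends the flat reading from the exchange of the amine to a change on the piperidine ring itself. No measurement is at hand that would explain this flat result.

On these data alone, whether a carboxylic acid or an amide on the same ring carbon, or a longer chain leading to the ring nitrogen, would give a step beyond the scatter stays open. Also open, as far as these compounds go, is whether these tails would stay equally flat on a changed core.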